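Replacing Phenyl with Pyrrolidin-1-yl on the Shared Core

This account rests on a few compounds, and the source may have more. Where it says the series, first, only, none or still open, it means among the compounds named here.

Measured so far in an ADME assay on THP-1 cells (Homo sapiens) for cytotoxicity, read by resazurin assay, with a stated time of 72 h; a lower number here means that less compound is tolerated, a higher number that more compound is tolerated:
Compound 1 `Cc1ccccc1C(=O)/C=C/c1ccc([N+](=O)[O-])o1`: 27900 nM
Compound 2 `O=C(/C=C/c1ccc([N+](=O)[O-])o1)c1ccc(-c2ccccc2)cc1`: 50400 nM

Only these two compounds have been measured. Compound 2, at 50400 nM, stands within the usual scatter of compound 1, at 27900 nM, so this assay does not separate them.

The next compound is compound 3 `O=C(/C=C/c1ccc([N+](=O)[O-])o1)c1ccc(N2CCCC2)cc1`, which has not yet been measured. It departs from compound 2 in one place: pyrrolidin-1-yl in place of phenyl on an aromatic carbon. In words, this is pyrrolidin-1-yl in place of phenyl on an aromatic carbon, para to a large group.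

Within the data shown here, no measured pair differs in one place, so the data offer no direct guide to the size of such a step. The expectation therefore rests on the two values alone, which lie close together, and it stays near them. The expected change is small and is not expected to clear the scatter: a 1.7-fold lower number from compound 2 to compound 3 (0.23 log units; within the scatter).

For compound 3 the estimated value is 30000 nM, with an expected range from 10000 nM to 80000 nM.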

Compound 3, half-maximal cytotoxic concentration: > 50000 nM
Compound 3 ended at the assay's limit; the forecaster's own chance of this, stated with the estimate: 10%; middle value at least 1.6-fold (0.22 log units) from the limit.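

In this assay compound 3 gives > 50000 nM, which is a limit of the assay and not a number. The step from compound 2 to compound 3 therefore cannot be read: the limit of > 50000 nM in this assay, at which 1 of the 3 values shown sits. The compounds shown leave open whether pyrrolidin-1-yl in place of phenyl on an aromatic carbon shifts the tolerated concentration at all, and by how much.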